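Fluorophenyl in Place of Naphthalenyl on a Shared Core

The source may report more compounds than this note shows. Statements on the series, on what has been measured and on what is new or still open speak of the compounds shown alone.

Compound 1 `c1ccc(-c2cn3ccnc3c(-c3ccc4ncn(C5CCCCC5)c4c3)n2)cc1`: 81.3%
Compound 2 `COc1ccc(-c2cn3ccnc3c(-c3ccc4ncn(C5CCCCC5)c4c3)n2)cc1`: 93.3%
Compound 3 `c1ccc2c(-c3cn4ccnc4c(-c4ccc5ncn(C6CCCCC6)c5c4)n3)cccc2c1`: 17.5%

In a functional assay on CCRF-CEM cells (Homo sapiens) for inhibition, read by sulforhodamine B assay, with a stated time of 48 h, tested at 10 uM (a lower number here means less inhibition, a higher number more inhibition at the concentration tested (going by the name of the read-out)), compound 3 stands lowest of the three, as the steps of a number 63.8 percentage points lower from compound 1 to compound 3 (beyond the scatter) and a number 75.8 percentage points lower from compound 2 to compound 3 (beyond the scatter) show. Compound 4 `Fc1ccc(-c2cn3ccnc3c(-c3ccc4ncn(C5CCCCC5)c4c3)n2)cc1` differs from it in one place: 4-fluorophenyl in place of naphthalen-1-yl on an aromatic carbon. The step most relevant is a number 63.8 percentage points lower from compound 1 to compound 3 (beyond the scatter), a large fall when naphthalen-1-yl replaced phenyl; compound 4 carries a phenyl again, now bearing fluorine. The step of a number 12 percentage points higher from compound 1 to compound 2 (beyond the scatter) shows that a small group on that phenyl gave a modest gain. A large rise is therefore expected, a number 66.5 percentage points higher from compound 3 to compound 4 (beyond the scatter). For compound 4 the estimate in this assay is 84%, with a range from 65% to 97%.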

Compound 4, a percentage reported as inhibition, at one concentration (the size of the read-out at that concentration, not a potency): 33.4%
Compound 4: middle estimate off by 50.6 percentage points, on the high side; the whole stated range lies above it.
By their numbers in this assay, from the lowest: compound 3; then compound 4; then compound 1; then compound 2.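

In this assay, a substituent on this phenyl can cut either way: fluoro in place of hydrogen gives a number 47.9 percentage points lower from compound 1 to compound 4 (beyond the scatter), whereas methoxy had brought a modest gain. Fluoro in place of methoxy gives a number 59.9 percentage points lower from compound 2 to compound 4 (beyond the scatter), so the two groups part widely at this one place. Replacing naphthalen-1-yl with 4-fluorophenyl gives only a number 15.9 percentage points higher from compound 3 to compound 4 (beyond the scatter), so a single aromatic ring here does not by itself restore the level of compound 1.

No available evidence accounts for this difference. As far as these compounds go, it remains open whether chloro, methyl, an amine or a carboxylic acid on that phenyl would track methoxy or fluoro.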